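Swapping methyl for methoxy in a small compound series

The source may report more compounds than this note shows. Statements on the series, on what has been measured and on what is new or still open speak of the compounds shown alone.

Measured in a functional assay on NCI/ADR-RES cells (Homo sapiens) for inhibition, read by sulforhodamine B assay, with a stated time of 48 h; on this read-out lower numbers stand for stronger inhibition of growth and higher numbers for weaker inhibition of growth:
- Compound 1 `S=C(N/N=C/c1cccs1)Nc1ccc(Cl)cc1`: 2800 nM
- Compound 2 `Cc1ccc(NC(=S)N/N=C/c2cccs2)cc1`: 4800 nM

Going by the values given here, compound 2, at 4800 nM, lies within the usual scatter of compound 1, the only other compound measured, so these two numbers cannot be ranked.

Compound 3 `COc1ccc(NC(=S)N/N=C/c2cccs2)cc1` has not yet been measured in this assay. It keeps the shared core and differs from compound 2 in one place: methoxy in place of methyl on an aromatic carbon. In words, this is methoxy in place of methyl on an aromatic carbon, para to a large group.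

Among the compounds with values here, only one measured step bears on this change. It puts methyl in place of chloro on an aromatic carbon and gives a 1.7-fold higher number from compound 1 to compound 2 (0.23 log units; within the scatter). Within the data shown here, that step is small, but it is a single guide, and no measured compound carries methoxy, so the range has to stay wide. No step beyond the scatter is expected in this assay.

The estimated change is a 1.1-fold lower number from compound 2 to compound 3 (0.06 log units; within the scatter). For compound 3 the expected value is 4200 nM, with an expected range of 1800 nM to 9500 nM.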

Compound 3, concentration for 50% growth inhibition: > 100000 nM
Compound 3: a limit, no number (the forecaster's own chance of this, stated with the estimate: 3%); at least 23-fold (1.37 log units) between middle value and limit.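

In this assay compound 3 gives > 100000 nM, which is a limit of the assay and not a number: the limit of > 100000 nM in this assay, at which 1 of the 3 values shown sits.

Methoxy in place of methyl gives an at least 20-fold higher number from compound 2 to compound 3 (1.31 log units; beyond the scatter), and methoxy in place of chloro gives an at least 35-fold higher number from compound 1 to compound 3 (1.55 log units; beyond the scatter), so both steps are large and lie beyond the scatter. The earlier step between chloro and methyl on this same aromatic carbon stayed within the scatter, which made the position look undemanding, whereas this result shows that the group placed there can matter greatly, at least when methoxy brings in one oxygen and one hydrogen-bond acceptor where methyl has none.

With only chloro, methyl and methoxy at this place, the compounds shown cannot tell whether the loss follows the oxygen itself or simply the group having two heavy atoms rather than one. On these data alone, an ethyl group, which has two heavy atoms and no oxygen, or a hydroxyl group, which has oxygen and no added carbon, would help separate these two readings, and how far compound 3 truly lies from the others also stays open.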